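The source may hold more compounds than are shown below. What is called first, only, known or untested is meant among the compounds shown, and "the series" means these compounds.

Compound 1 `Cc1cc(-c2ccccc2)cn2c(CSCCc3ccccc3)cnc12` gives 20 ug/mL. Compound 2 `Cc1cc(-c2ccsc2)cn2c(CSCCc3ccccc3)cnc12` gives >= 4 ug/mL, a limit of the assay. Compound 3 `Cc1cc(-c2cccc([N+](=O)[O-])c2)cn2c(CSCCc3ccccc3)cnc12` gives >= 100 ug/mL, also a limit.

In an ADME assay on HEL cells (Homo sapiens) for cytotoxicity, with a stated time of 3 days (a higher number here means that more compound is tolerated, a lower number that less compound is tolerated), compound 3 therefore stands at a limit, (the limit of >= 100 ug/mL in this assay, at which 1 of the 3 values shown sits), and not at a number; of the three values shown, one other is a limit as well. The step of an at least 5.0-fold higher number from compound 1 to compound 3 (0.69 log units; beyond the scatter) is the only one with a readable size; a step that the two limits leave unreadable from compound 2 to compound 3 cannot be read because compound 2 sits at the other limit, (the limit of >= 4 ug/mL in this assay, at which 1 of the 3 values shown sits). Compound 4 `Cc1cc(Br)cn2c(CSCCc3ccccc3)cnc12` differs from compound 3 by bromo in place of 3-nitrophenyl on an aromatic carbon. Among the measured compounds shown here, no measured step covers a change of this kind, so the expectation leans on compound 1 and compound 3. Compound 4 is expected near 50 ug/mL, between 10 ug/mL and 100 ug/mL. That would be an estimated step of an at least 2.0-fold lower number from compound 3 to compound 4 (0.30 log units; that floor lies within the scatter).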

Compound 4, minimum cytotoxic concentration: >= 2 ug/mL
Compound 4: no number, only a limit (the forecaster's own chance of this, stated with the estimate: 40%); the middle value is on the limit's open side.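

In this assay compound 4 gives >= 2 ug/mL, a limit and not a number. Its steps from compound 1, compound 2 and compound 3 cannot be read. The compounds shown leave open how bromo compares with phenyl, thiophen-3-yl or 3-nitrophenyl.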